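The source may hold more compounds than are shown below. What is called first, only, known or untested is meant among the compounds shown, and "the series" means these compounds.

Two close relatives set the stage. Compound 1 `Nc1c(C(=O)NC2CCCC2)oc2nc(-c3ccccc3)cc(C(F)(F)F)c12` carries a cyclopentyl group on its amide nitrogen, and in an ADME assay on HEK293 cells (Homo sapiens) for antiproliferative activity, read by MTT assay (a lower number here means a stronger inhibitor, a higher number a weaker inhibitor), compound 1 gives 85000 nM. Compound 2 `CCNC(=O)c1oc2nc(-c3cccs3)cc(C(F)(F)F)c2c1N`, which pairs an ethyl group on the amide nitrogen with a thiophene in place of the phenyl, gives 62000 nM in this assay. These two numbers lie within the scatter of each other, so neither compound can be called the stronger or the weaker of the pair; compound 1 simply has the higher of the two numbers recorded so far.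

Compound 3 `CCCNC(=O)c1oc2nc(-c3ccccc3)cc(C(F)(F)F)c2c1N` is the next point on the path. Its difference from compound 1 is a single change: propyl in place of cyclopentyl on an amide-type nitrogen. Among the measured compounds shown here, no measured pair in this small set shows the same swap, so there is no direct precedent for its effect. Both measured compounds are weak in this assay, and the change keeps the rest of the molecule untouched, so the step from compound 1 to compound 3 in this assay is expected to stay within the scatter, with no direction favoured: a 1.1-fold higher number from compound 1 to compound 3 (0.02 log units; within the scatter). On that basis compound 3 is estimated at 90000 nM, with a range from 40000 nM to 200000 nM.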

Compound 3, half-maximal inhibitory concentration: 81000 nM
Compound 3: middle estimate off by 1.1-fold (0.05 log units), on the high side; the measured number falls inside the stated range.
By their numbers in this assay, from the lowest: compounds 2, 3 and 1 (each within the scatter of the next).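

Among the compounds shown here, compound 3 gives the first reading of a single change at this position: with the rest of the molecule held fixed, replacing the cyclopentyl ring on the amide-type nitrogen with an open propyl chain gives (a 1.0-fold lower number from compound 1 to compound 3 (0.02 log units; within the scatter)) in this assay. Removing the ring and going from 5 heavy atoms to 3 therefore produces no readable change in this assay, and the pair stays at the weak end of the scale seen so far. Nothing available here accounts for this lack of change.

This single swap replaces one plain carbon group with another, so it leaves open whether a longer chain, such as octyl, or a chain ending in an amine or a carboxylic acid would move the number beyond the scatter. It also leaves open whether the same swap would behave in the same way alongside the thiophene of compound 2, where the ethyl group on the amide nitrogen comes with a second difference and cannot be judged on its own.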